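The source may hold more compounds than are shown below. What is called first, only, known or untested is meant among the compounds shown, and "the series" means these compounds.

Working notes on the series. In an assay on isolated protein (Cavia porcellus) with Sigma non-opioid intracellular receptor 1 (Homo sapiens) as the target, read by radioligand binding (a lower number here means a stronger inhibitor, a higher number a weaker inhibitor), compound 1 `O=c1cc(-c2ccccc2)oc2cccc(OCCCCN3CCC(O)CC3)c12` gives 58 nM and compound 2 `O=c1cc(-c2ccccc2)oc2cccc(OCCCCCCCN3CCC(O)CC3)c12` gives 36 nM; the step of a 1.6-fold lower number from compound 1 to compound 2 (0.21 log units; within the scatter) lengthens the chain under the same amine and stays within the scatter. Compound 3 `CN(C)CCCCCCCCOc1ccc2oc(-c3ccccc3)cc(=O)c2c1` gives 227 nM, the highest number of the three, beyond the scatter from both compound 1 and compound 2. Compound 4 `O=c1cc(-c2ccccc2)oc2ccc(OCCCCCCN3CCC(O)CC3)cc12` differs from compound 3 by 4-hydroxypiperidin-1-yl in place of 2-(dimethylamino)ethyl on a saturated chain carbon, six bonds along the chain from an oxygen on an aromatic ring, so the chain is shortened and the amine head is exchanged. Among the compounds with values here, no measured step changes the amine head, so the step is set mainly by compound 3 standing above compound 1 and compound 2. A lower number in this assay is therefore expected for compound 4, by roughly a 4.1-fold lower number from compound 3 to compound 4 (0.62 log units; beyond the scatter), so that compound 4 is estimated at 55 nM with a range of 20 nM to 160 nM.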

Compound 4, half-maximal inhibitory concentration: 100 nM
Compound 4: middle estimate off by 1.8-fold (0.26 log units), on the low side, and the stated range covers the measured number.
By their numbers in this assay, from the lowest: compounds 2, 1 and 4 (each within the scatter of the next, the first and the last beyond it); then compound 3.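

In this assay, within the data shown here, 4-hydroxypiperidin-1-yl in place of 2-(dimethylamino)ethyl gives a 2.3-fold lower number from compound 3 to compound 4 (0.36 log units; beyond the scatter), so the one step here that exchanges the amine head moves the number beyond the scatter. The same exchange also shortens the chain, and this step cannot separate the two changes. Nothing available bears on the reason for the step.

Open, going by these compounds, is whether 4-hydroxypiperidin-1-yl on the longer chain of compound 3 would give the same step. Also open, on these data alone, is how an unsubstituted piperidine or a morpholine would compare on the chain of compound 4.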